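Working notes: from compound 1 to compound 3

This account rests on a few compounds, and the source may have more. Where it says the series, first, only, none or still open, it means among the compounds named here.

In a functional assay on KB-VIN10 cells (Homo sapiens) for inhibition, with a stated time of 72 h (a higher number here means a weaker inhibitor, a lower number a stronger inhibitor), compound 1 (`COc1ccc(S(=O)(=O)N2CCc3cccc(-c4ccc(N(C)C)cc4)c32)cc1`) gives 553 nM. Compound 2 (`COc1ccc(S(=O)(=O)n2ccc3cccc(-c4ccc(F)cc4)c32)cc1`) gives 202 nM. For the measured compounds named here, compound 1 has the higher of the two numbers so far, and the gap between them lies beyond the scatter. Compound 3 (`COc1ccc(S(=O)(=O)N2CCc3cccc(-c4ccc(O)cc4)c32)cc1`) carries hydroxy in place of dimethylamino on an aromatic carbon, para to a large group (hydroxy in place of dimethylamino on an aromatic carbon). Going by the values given here, no measured step gauges this change, so no step beyond the scatter is expected in this assay. The expected change is a 1.4-fold lower number from compound 1 to compound 3 (0.14 log units; within the scatter). For compound 3 the estimated value is 400 nM, with an expected range from 130 nM to 1300 nM.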

Compound 3, half-maximal inhibitory concentration: 123 nM
Estimate against measurement, compound 3: 3.3-fold (0.51 log units) above; measured number outside the range, below it.
By their numbers in this assay, from the lowest: compounds 3 and 2 (each within the scatter of the next); then compound 1.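

In this assay, hydroxy in place of dimethylamino gives a 4.5-fold lower number from compound 1 to compound 3 (0.65 log units; beyond the scatter), so the substituent on this aromatic carbon alters the number, which compound 1 and compound 2 could not show as they differ in more than one place. Heavy-atom count and hydrogen-bond donor count change together in this single step, so it cannot assign the shift to either one. No measurement at hand bears on why the number falls.

Methoxy or an amine at this place would help separate those two changes. On these data alone, whether hydroxy gives a similar step on the core of compound 2 also remains open.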